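The source may hold more compounds than are shown below. What is called first, only, known or untested is meant among the compounds shown, and "the series" means these compounds.

Compound 1 `CCCCCCn1cnc2c(Nc3ccc(O)cc3)nc(N[C@H]3CC[C@H](N)CC3)nc21`: in a functional assay on HCC827 cells (Homo sapiens) for inhibition, read by fluorescence, with a stated time of 72 h (a higher number here means a weaker inhibitor of growth, a lower number a stronger inhibitor of growth), compound 1 gives 24700 nM.
Compound 2 `CC(C)CCn1cnc2c(NCc3cccc(Cl)c3)nc(N[C@H]3CC[C@H](N)CC3)nc21`: in this assay compound 2 gives 16700 nM.
Compound 3 `N[C@H]1CC[C@H](Nc2nc(Nc3ccc(O)cc3)c3ncn(C4CCCCC4)c3n2)CC1`: in this assay compound 3 gives 32500 nM.

Compound 3 carries the highest of the three numbers in this assay, but the others sit close to it: the step of a 1.3-fold higher number from compound 1 to compound 3 (0.12 log units; within the scatter) is within the scatter, and the number for compound 2 also lies within the scatter of compound 3, so no order among the three can be read from these values.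

Compound 4 `CC(C)CCn1cnc2c(Nc3ccc(O)cc3)nc(N[C@H]3CC[C@H](N)CC3)nc21` has not yet been measured in this assay. It differs from compound 3 in one place: isopentyl in place of cyclohexyl on an aromatic nitrogen. Within the data shown here, the only measured step at this position is a 1.3-fold higher number from compound 1 to compound 3 (0.12 log units; within the scatter), which stayed within the scatter when hexyl was exchanged for cyclohexyl. Compound 2 carries isopentyl at the same nitrogen but differs elsewhere, so its value is only a loose pointer. The step of a 1.3-fold lower number from compound 3 to compound 4 (0.11 log units; within the scatter) is therefore expected to stay within the scatter, perhaps leaning to a lower number. Compound 4 is estimated at 25000 nM, with a range from 10000 nM to 60000 nM.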

Compound 4, concentration for 50% growth inhibition: 14400 nM
The estimate for compound 4 lay 1.7-fold (0.24 log units) above the measured number; the measured number falls inside the stated range.
By their numbers in this assay, from the lowest: compounds 4, 2, 1 and 3 (each within the scatter of the next, the first and the last beyond it).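

In this assay, among these compounds, isopentyl in place of cyclohexyl on the aromatic nitrogen gives a 2.3-fold lower number from compound 3 to compound 4 (0.35 log units; beyond the scatter) and so provides the first modest step at this position that can be read, whereas the exchange of hexyl for cyclohexyl gave only a 1.3-fold higher number from compound 1 to compound 3 (0.12 log units; within the scatter). The two open chains cannot be told apart, since the change from compound 1 gives a 1.7-fold lower number from compound 1 to compound 4 (0.23 log units; within the scatter). With isopentyl held fixed, 4-hydroxyphenyl in place of 3-chlorobenzyl on the nitrogen on the aromatic ring gives a 1.2-fold lower number from compound 2 to compound 4 (0.06 log units; within the scatter), so this exchange shows no readable effect in these cells.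

Nothing available explains why the cyclohexyl and isopentyl compounds differ. From the compounds shown here alone, whether a shorter chain such as ethyl, or an amine or a carboxylic acid at the end of the chain, would move the number further remains open.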